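The source may hold more compounds than are shown below. What is called first, only, known or untested is meant among the compounds shown, and "the series" means these compounds.

Compound 1 `COc1ccc(Nc2nc3ccccc3nc2S(=O)(=O)c2ccc(C)cc2)cc1` in a functional assay on PC-3 cells (Homo sapiens) for cytotoxicity, read by MTT assay, with a stated time of 72 h; a higher number here means a weaker inhibitor, a lower number a stronger inhibitor: > 50000 nM
Compound 2 `COc1cc(Nc2nc3ccccc3nc2S(=O)(=O)c2ccc(C)cc2)cc(OC)c1`: 2940 nM
Compound 3 `COc1ccc(Nc2nc3ccccc3nc2S(=O)(=O)c2ccc(F)cc2)cc1`: 4330 nM

The value for compound 1 is a limit of this assay, not a number, (the limit of > 50000 nM in this assay, at which 1 of the 3 values shown sits). Compound 2 and compound 3 give numbers that lie within the usual scatter of each other, so they are not ranked here.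

Compound 2 differs from compound 1 by 3,5-dimethoxyphenyl in place of 4-methoxyphenyl on a nitrogen on an aromatic ring. That change gives an at least 17-fold lower number from compound 1 to compound 2 (1.23 log units; beyond the scatter). Compound 3 differs from compound 1 by fluoro in place of methyl on an aromatic carbon, which gives an at least 11-fold lower number from compound 1 to compound 3 (1.06 log units; beyond the scatter).

Compound 4 `COc1cc(Nc2nc3ccccc3nc2S(=O)(=O)c2ccc(F)cc2)cc(OC)c1` has not yet been measured in this assay. It differs from compound 3 by 3,5-dimethoxyphenyl in place of 4-methoxyphenyl on a nitrogen on an aromatic ring, the same change already seen between compound 1 and compound 2, at a place described in the same words. The two cores differ by fluoro in place of methyl on an aromatic carbon.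

Among the measured compounds shown here, for compound 4 a step of about a 4.3-fold lower number from compound 3 to compound 4 (0.64 log units; beyond the scatter) is expected, somewhat smaller than the one seen between compound 1 and compound 2, because that earlier step starts from a limit of > 50000 nM in this assay, at which 1 of the 3 values shown sits, and its true size is not known. A further reason for the smaller expected step is that compound 3 already sits at 4330 nM. On this basis compound 4 is estimated at 1000 nM, with a likely range from 300 nM to 4000 nM.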

Compound 4, half-maximal inhibitory concentration: 4530 nM
For compound 4 the middle estimate is 4.5-fold (0.66 log units) below the measured one; the whole stated range lies below it.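

In this assay, the change from 4-methoxyphenyl to 3,5-dimethoxyphenyl gives a 1.0-fold higher number from compound 3 to compound 4 (0.02 log units; within the scatter) on the core carrying fluoro, so the large step seen on the core carrying methyl does not carry over: the same change on two cores in this assay, an at least 17-fold lower number (1.23 log units; beyond the scatter) from compound 1 to compound 2 and a 1.0-fold higher number (0.02 log units; within the scatter) from compound 3 to compound 4, at least 17-fold (1.25 log units) apart, beyond the scatter of two such steps. The change from methyl to fluoro behaves in the same way, giving a 1.5-fold higher number from compound 2 to compound 4 (0.19 log units; within the scatter) on the core carrying 3,5-dimethoxyphenyl, so neither change acts as a fixed step that can simply be added to the other in these four compounds: the same change on two cores in this assay, an at least 11-fold lower number (1.06 log units; beyond the scatter) from compound 1 to compound 3 and a 1.5-fold higher number (0.19 log units; within the scatter) from compound 2 to compound 4, at least 17-fold (1.25 log units) apart, beyond the scatter of two such steps. Compound 1 gives > 50000 nM, which is a limit and not a number, so the true size of both gaps stays unknown, and the values alone do not show why the steps differ: the limit of > 50000 nM in this assay, at which 1 of the 4 values shown sits.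

Compounds 2, 3 and 4 lie within the usual scatter of one another, which leaves open whether any other group could separate itself from them, for example chloro or a nitrile in place of the fluoro, or an amine in place of a methoxy group. From the compounds shown here alone, it also remains open whether the same lack of carry-over would appear on cores other than these two.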